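The compounds below may be only part of what the source reports. "The series", "measured", "known", "first", "only" and "open" are said of these compounds alone.

For the measured compounds named here, compound 2 `O=C(N/N=C/c1ccccc1)c1ccc(-c2nc3ccccc3s2)cc1` gives 8050 nM in an assay on isolated protein for inhibition of Maltase-glucoamylase (Homo sapiens), with a stated time of 15 min (a higher number here means a weaker inhibitor, a lower number a stronger inhibitor), the higher of the two numbers measured so far. Its neighbour, compound 1 `O=C(N/N=C/c1ccccc1O)c1ccc(-c2nc3ccccc3s2)cc1`, gives 5550 nM in this assay, and the change from compound 1 to compound 2 was a 1.5-fold higher number from compound 1 to compound 2 (0.16 log units; within the scatter). Compound 3 `O=C(N/N=C/c1ccc(F)c(Br)c1)c1ccc(-c2nc3ccccc3s2)cc1` differs from compound 2 by 3-bromo-4-fluorophenyl in place of phenyl on a carbon with a double bond to nitrogen. Going by the values given here, the only measured step concerns the same ring but a different substituent, and it stayed within the scatter, so for compound 3 a step of about a 1.2-fold lower number from compound 2 to compound 3 (0.06 log units; within the scatter) is expected, with no clear direction. Compound 3 is therefore estimated at 7000 nM, between 3000 nM and 16000 nM.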

Compound 3, half-maximal inhibitory concentration: 28000 nM
Compound 3: middle estimate off by 4.0-fold (0.60 log units), on the low side; measured number outside the range, above it.
By their numbers in this assay, from the lowest: compounds 1 and 2 (each within the scatter of the next); then compound 3.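

In this assay, for the compounds shown here, the ring on the carbon with a double bond to nitrogen does affect the result: 3-bromo-4-fluorophenyl in place of phenyl gives the first step beyond the scatter (a 3.5-fold higher number from compound 2 to compound 3 (0.54 log units; beyond the scatter)). The comparison with 2-hydroxyphenyl points the same way (a 5.0-fold higher number from compound 1 to compound 3 (0.70 log units; beyond the scatter)), so this position does not accept every substituted ring without a loss. Nothing available explains the rise.

Bromine and fluorine enter together, so the share of each remains open. Also open, from the compounds shown here alone, is how a ring carrying an amine or a carboxylic acid would behave here.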